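Urea substituent swap on a chloropyrazine series: compound 4

The source may report more compounds than this note shows. Statements on the series, on what has been measured and on what is new or still open speak of the compounds shown alone.

Compound 1 `CN(C)c1ccc(NC(=O)Nc2cccc(CNc3nccnc3Cl)c2)cc1`: 11500 nM
Compound 2 `O=C(Nc1cccc(CNc2nccnc2Cl)c1)NC1CCCC1`: 23400 nM
Compound 3 `O=C(Nc1cccc(CNc2nccnc2Cl)c1)Nc1ccc(Cl)c(Cl)c1`: 4970 nM

Among these three, compound 1 holds the second highest number in a functional assay on MGC-803 cells (Homo sapiens) for antiproliferative activity, read by MTT assay, with a stated time of 48 h; a lower number here means a stronger inhibitor, a higher number a weaker inhibitor; compound 2 lies above it by a 2.0-fold higher number from compound 1 to compound 2 (0.31 log units; beyond the scatter), and compound 3 lies below it by a 2.3-fold lower number from compound 1 to compound 3 (0.36 log units; beyond the scatter). Compound 4 `O=C(Nc1cccc(CNc2nccnc2Cl)c1)Nc1ccccc1Cl` follows from compound 1 through (2-chlorophenyl in place of 4-(dimethylamino)phenyl on an amide-type nitrogen). The step to compound 3 is the closest guide, since it also brings a chlorinated phenyl onto that nitrogen, while the step to compound 2 shows that a non-aromatic group costs potency. A single chlorine, rather than two, is expected to give a smaller gain than compound 3 showed, so a modest lowering of a 1.4-fold lower number from compound 1 to compound 4 (0.16 log units; within the scatter) is expected. Compound 4 is therefore estimated at 8000 nM, in the range 3500 nM to 18000 nM.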

Compound 4, half-maximal inhibitory concentration: 7130 nM
Compound 4: middle estimate off by 1.1-fold (0.05 log units), on the high side; low and high end bracket the measured number.
By their numbers in this assay, from the lowest: compounds 3, 4 and 1 (each within the scatter of the next, the first and the last beyond it); then compound 2.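

The 2-chlorophenyl group gives a 1.6-fold lower number from compound 1 to compound 4 (0.21 log units; within the scatter) and a 1.4-fold higher number from compound 3 to compound 4 (0.16 log units; within the scatter), so compound 4 cannot be told apart from either of these two phenyl-bearing compounds. Against the cyclopentyl group it gives a 3.3-fold lower number from compound 2 to compound 4 (0.52 log units; beyond the scatter), which places a third substituted phenyl clear of compound 2, with no compound shown going against that pattern. Nothing available explains these steps. Still open, going by these compounds, is how a pyridyl ring, or a phenyl carrying a carboxylic acid or a methoxy group, would compare on that amide-type nitrogen.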